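This account rests on a few compounds, and the source may have more. Where it says the series, first, only, none or still open, it means among the compounds named here.

Compound 1 `Cc1ccccc1N1CCN(CCCCNC(=O)c2ccc3ccccc3c2)CC1`: in an assay on isolated protein for displacement of a labelled ligand from Alpha-1A adrenergic receptor (Homo sapiens) (a higher number here means a weaker inhibitor, a lower number a stronger inhibitor), compound 1 gives 29.9 nM.
Compound 2 `COc1ccccc1N1CCN(CCCCNC(=O)N(C)c2ccccc2)CC1`: compound 2 gives 116 nM.
Compound 3 `O=C(NCCCCN1CCN(c2cccc(C(F)(F)F)c2)CC1)c1ccc2ccccc2c1`: compound 3 gives 283 nM.

Compound 1 thus carries the lowest number of the three, and both other values lie beyond the scatter from it. Compound 4 `O=C(NCCCCN1CCN(c2cccc3[nH]c(=O)[nH]c23)CC1)c1ccc2ccccc2c1` has not been measured. It differs from compound 1 in one place: a group of 10 heavy atoms (7 carbon, 2 nitrogen, 1 oxygen; one five-membered aromatic ring with 2 hetero atoms, one six-membered aromatic ring of carbon only) in place of a group of 7 heavy atoms (7 carbon; one six-membered aromatic ring of carbon only), on an amine nitrogen in a ring. Within the data shown here, the only measured step at the same place is a 9.5-fold higher number from compound 1 to compound 3 (0.98 log units; beyond the scatter), so swapping the group on that ring nitrogen has already moved the number once, though with a different group. The present change is larger and brings in hydrogen-bond donors and an acceptor, so a modest rise is expected for compound 4, a 2.7-fold higher number from compound 1 to compound 4 (0.43 log units; beyond the scatter). For compound 4 the estimate is 80 nM, with a range from 15 nM to 400 nM.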

Compound 4, inhibition constant: 158 nM
For compound 4 the middle estimate is 2.0-fold (0.30 log units) below the measured one, and the stated range covers the measured number.
By their numbers in this assay, from the lowest: compound 1; then compounds 2, 4 and 3 (each within the scatter of the next, the first and the last beyond it).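

In this assay, the larger group with a five-membered aromatic ring and hydrogen-bond donors also does worse on the ring nitrogen than 2-methylphenyl, with a 5.3-fold higher number from compound 1 to compound 4 (0.72 log units; beyond the scatter) for this swap. Against 3-(trifluoromethyl)phenyl it gives a 1.8-fold lower number from compound 3 to compound 4 (0.25 log units; within the scatter) in this comparison, so these two very different groups cannot be told apart, and 2-methylphenyl keeps the lowest number of the three. Nothing available explains these differences. Still open, as far as these compounds go, is how a plain phenyl, a 3-methylphenyl or a 2-chlorophenyl on that nitrogen would compare with 2-methylphenyl.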